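One Fluorine Less: Expected Cytotoxicity of Compound 3

This account rests on a few compounds, and the source may have more. Where it says the series, first, only, none or still open, it means among the compounds named here.

Compound 1 `NC(=S)N/N=C(\COc1ccccc1)c1ccc(Br)cc1` gives 54900 nM in an ADME assay on L929 cells (Mus musculus) for cytotoxicity, read by resazurin assay, with a stated time of 96 h; on this read-out lower numbers stand for higher toxicity in this test and higher numbers for lower toxicity in this test.
Compound 2 `NC(=S)N/N=C(\COc1ccc(F)c(Cl)c1)c1ccc(Br)cc1` gives 48000 nM in this assay.

Among the compounds with values here, only two compounds have been measured so far, and they sit close together. Compound 2 has the lowest of the two numbers, but its nearest neighbour is compound 1, and the gap between them lies within the usual scatter of repeated measurements, so the two cannot be ranked against each other. Within the data shown here, no step between measured compounds that differ in only one place has been recorded, so there is no measured pattern to lean on.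

Compound 3 `NC(=S)N/N=C(\COc1cccc(Cl)c1)c1ccc(Br)cc1` is the next to be measured. It differs from compound 2 in one place: hydrogen in place of fluoro on an aromatic carbon. Compound 1 carries neither the chloro nor the fluoro group and still lands near compound 2, which suggests that this part of the molecule changes little in this assay. Compound 3 is therefore expected to show no step beyond the scatter, with a 1.0-fold higher number from compound 2 to compound 3 (0.02 log units; within the scatter) as the estimated shift. For compound 3 the estimate is 50000 nM, with a plausible range from 25000 nM to 100000 nM.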

Compound 3, half-maximal cytotoxic concentration: < 50200 nM
Compound 3 was reported as a limit; the forecaster's own chance of this, stated with the estimate: 5%; the middle value is on the limit's open side.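

In this assay compound 3 gives < 50200 nM, which is a limit and not a number. The step from fluoro to hydrogen at this position cannot be read, because the only figure for compound 3 is a limit: the limit of < 50200 nM in this assay, at which 1 of the 3 values shown sits.

The one comparison that can be read is the other single change, chloro in place of hydrogen on an aromatic carbon, which gives an at least 1.0-fold lower number from compound 1 to compound 3 (0.03 log units; that floor lies within the scatter); the chloro group is therefore not shown to move this read-out beyond the scatter, though a larger drop is not ruled out.

The compounds shown leave open what the fluoro group alone does at this place, and how far compound 3 really lies from its two neighbours. They also leave open how this assay responds when a different kind of group stands on this aromatic carbon, such as an amine, a carboxylic acid or a longer chain.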